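This account rests on a few compounds, and the source may have more. Where it says the series, first, only, none or still open, it means among the compounds named here.

Compounds measured so far in a physicochemical assay for lipophilicity, using the shake flask method, in phosphate buffer, measured as octanol-water partition, with a stated time of 30 min, at pH 7.4; on this read-out lower numbers stand for lower lipophilicity and higher numbers for higher lipophilicity:
- compound 1 `O=C1c2ccccc2CN1c1cnc(NCc2c(F)ccc3c2CCO3)n2cnnc12`: 2.7
- compound 2 `O=C1CC2(CC2)CN1c1cnc(NCc2c(F)ccc3c2CCO3)n2cnnc12`: 1.9

For the measured compounds named here, of these two, compound 2 stands lowest, with compound 1 giving the higher number, and the one step between them, a number 0.80 log units lower from compound 1 to compound 2 (beyond the scatter), is beyond the scatter.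

Compound 3 `CN(c1cccnc1)c1cnc(NCc2c(F)ccc3c2CCO3)n2cnnc12` differs from compound 2 in one place: a group of 8 heavy atoms (6 carbon, 2 nitrogen; one six-membered aromatic ring with 1 hetero atom) in place of a group of 8 heavy atoms (6 carbon, 1 nitrogen, 1 oxygen; one three-membered non-aromatic ring of carbon only, one five-membered non-aromatic ring with 1 hetero atom), on an aromatic carbon. The group that leaves is the same group that entered in the step from compound 1 to compound 2, so that step is the only one that bears on the change. It shows that swapping a group with a six-membered aromatic ring of carbon only for the group with the three-membered ring lowered the number by a modest amount. The group entering in compound 3 again brings a six-membered aromatic ring, though one with a ring nitrogen and no carbonyl. A modest rise is therefore expected, roughly of the size seen before but possibly smaller, as a number 0.50 log units higher from compound 2 to compound 3 (beyond the scatter). Compound 3 is expected to give about 2.4, within a range from 1.8 to 3.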

Compound 3, distribution coefficient: 2.6
Beside the measured number, compound 3's estimate is 0.20 log units below it; measured number inside the range.
By their numbers in this assay, from the lowest: compound 2; then compounds 3 and 1 (each within the scatter of the next).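

In this assay, methyl(pyridin-3-yl)amino on this aromatic carbon, in place of the group with the three-membered ring, gives a number 0.70 log units higher from compound 2 to compound 3 (beyond the scatter) and so undoes most of the earlier fall. Set against the group of compound 1, the same change gives a number 0.10 log units lower from compound 1 to compound 3 (within the scatter), so two groups that differ in their heavy atoms and rings cannot be told apart here, and among these three compounds, only compound 2, whose group lacks a six-membered aromatic ring, stands apart from the others. No measurement shown accounts for these shifts.

Still open, on these data alone, is how methyl(phenyl)amino, with carbon in place of the ring nitrogen, would read in this assay. The same holds for pyridin-3-ylamino, which lacks the methyl on the linking nitrogen.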